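Compound 3: 1,3-thiazol-2-yl on the sulfonamide nitrogen

The source may hold more compounds than are shown below. What is called first, only, known or untested is meant among the compounds shown, and "the series" means these compounds.

Measured in a functional assay on OVCAR-3 cells (Homo sapiens) for antiproliferative activity, read by sulforhodamine B assay, with a stated time of 72 h; on this read-out higher numbers stand for weaker inhibition and lower numbers for stronger inhibition:
compound 1 `Cc1cc(C)nc(NS(=O)(=O)c2ccc(Nc3nncc4ccccc34)cc2)n1`: 3.4 nM
compound 2 `O=S(=O)(Nc1ncccn1)c1ccc(Nc2nncc3ccccc23)cc1`: 72 nM

Compound 2, at 72 nM, has the higher of the two numbers, and its gap to the other compound lies beyond the scatter. Compound 3 `O=S(=O)(Nc1nccs1)c1ccc(Nc2nncc3ccccc23)cc1` is the next to consider, and it differs from compound 2 in one place: 1,3-thiazol-2-yl in place of pyrimidin-2-yl on a sulfonamide nitrogen. In words, this is 1,3-thiazol-2-yl in place of pyrimidin-2-yl on a sulfonamide nitrogen.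

Going by the values given here, only one measured step bears on this place: a 21-fold higher number from compound 1 to compound 2 (1.33 log units; beyond the scatter). This large step came with pyrimidin-2-yl in place of 4,6-dimethylpyrimidin-2-yl. Among the compounds with values here, it shows that the read-out can move strongly with a change on this nitrogen, but no measured compound carries 1,3-thiazol-2-yl, so the direction for compound 3 remains weakly founded. A smaller step than that one is expected, tentatively towards a lower number, and it may not clear the scatter.

The expected change is a 1.8-fold lower number from compound 2 to compound 3 (0.26 log units; within the scatter). For compound 3 the estimated value is 40 nM, with an expected range of 10 nM to 150 nM.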

Compound 3, half-maximal inhibitory concentration: 43 nM
Estimate against measurement, compound 3: 1.1-fold (0.03 log units) below; the range from low to high includes it.
By their numbers in this assay, from the lowest: compound 1; then compounds 3 and 2 (each within the scatter of the next).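

In this assay, a five-membered aromatic ring, 1,3-thiazol-2-yl, on the sulfonamide nitrogen in place of the six-membered pyrimidin-2-yl gives a 1.7-fold lower number from compound 2 to compound 3 (0.22 log units; within the scatter), so this change of ring does not separate the two compounds on this read-out. The large gap to the 4,6-dimethylpyrimidin-2-yl group persists with the new ring, at a 13-fold higher number from compound 1 to compound 3 (1.10 log units; beyond the scatter), alongside the earlier 21-fold higher number from compound 1 to compound 2 (1.33 log units; beyond the scatter); among the three compounds, only compound 1 reaches the low end of the range, and neither ring without methyl groups approaches it. Nothing available explains either the flat step between the two rings or the large gap to compound 1.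

From the compounds shown here alone, it remains open whether a single methyl on pyrimidin-2-yl would be enough to recover the value of compound 1, or whether both methyl groups are needed. Also unresolved is whether methyl on 1,3-thiazol-2-yl would produce a comparable shift, and how larger groups on the pyrimidine, such as ethyl, methoxy or an amine, would behave on this nitrogen.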